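Swapping the aryl on the triazole: compound 3 estimated

The source may report more compounds than this note shows. Statements on the series, on what has been measured and on what is new or still open speak of the compounds shown alone.

Compound 1 `COc1ccc(-n2cc(COc3c(/C=C\C(=O)O)ccc(OC)c3CC=C(C)C)nn2)cc1` gives 8700 nM in a functional assay on HCT-116 cells (Homo sapiens) for cytotoxicity, read by MTT assay, with a stated time of 24 h (on this read-out lower numbers stand for stronger inhibition and higher numbers for weaker inhibition), the lowest of the two numbers shown; compound 2 `COc1ccc(/C=C\C(=O)O)c(OCc2cn(-c3cccnc3Cl)nn2)c1CC=C(C)C` gives 23000 nM. The step of a 2.6-fold higher number from compound 1 to compound 2 (0.42 log units; beyond the scatter) is the only one that bears on the change to compound 3 `COc1ccc(/C=C\C(=O)O)c(OCc2cn(-c3ccccc3C#N)nn2)c1CC=C(C)C`, in which (2-cyanophenyl in place of 4-methoxyphenyl on an aromatic nitrogen). Within the data shown here, since the one comparable swap of the aryl on that nitrogen weakened inhibition modestly, a step of similar size and direction is expected, a 1.7-fold higher number from compound 1 to compound 3 (0.24 log units; within the scatter). Compound 3 is therefore estimated at 15000 nM, within a range of 6000 nM to 40000 nM.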

Compound 3, half-maximal inhibitory concentration: 38300 nM
For compound 3 the middle estimate is 2.6-fold (0.41 log units) below the measured one; the range from low to high includes it.
By their numbers in this assay, from the lowest: compound 1; then compounds 2 and 3 (each within the scatter of the next).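

In this assay, a second replacement for 4-methoxyphenyl on the aromatic nitrogen also moves away from compound 1, with a 4.4-fold higher number from compound 1 to compound 3 (0.64 log units; beyond the scatter), so the earlier loss is no longer a single case. The two replacements cannot be told apart, with a 1.7-fold higher number from compound 2 to compound 3 (0.22 log units; within the scatter). The data shown give no reason for the loss. On these data alone, whether the methoxy group itself or its place on the ring matters remains open; 2-methoxyphenyl, plain phenyl or 4-aminophenyl on that nitrogen would bear on this.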